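Replacing a saturated ring with an unsaturated one on the shared core

The source may report more compounds than this note shows. Statements on the series, on what has been measured and on what is new or still open speak of the compounds shown alone.

Of the compounds shown here, three with a shared core have been measured in an assay on HEK293 cells for inhibition of Voltage-dependent N-type calcium channel subunit alpha-1B (Homo sapiens), read by fluorescence and calcium flux, with a stated time of 5 min; on this read-out lower numbers stand for stronger inhibition and higher numbers for weaker inhibition. Compound 3 `COc1ccccc1-n1nc(C2C[C@H](C)O[C@@H](C)C2)cc1-c1ccc(Cl)cc1` gives 2 nM. Compound 2 `CCOc1ccc(-c2cc(C3CC(C)(C)OC(C)(C)C3)nn2-c2ccccc2OC)cc1` gives 2 nM, level with compound 3 at the digits shown, and together these two are the lowest of the three numbers. Compound 1 `COc1ccccc1-n1nc([C@H]2C[C@@H](C)O[C@@H](C)C2)cc1-c1ccc(Cl)cc1` gives 3 nM; the step of a 1.5-fold lower number from compound 1 to compound 3 (0.18 log units; within the scatter) lies within the scatter, and the two compounds differ only in how their stereocentres are drawn (the fact that one of compounds 1 and 3 is drawn with a defined configuration and the other without, at the place where they differ).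

Compound 4 `COc1ccccc1-n1nc(C2=CC(C)(C)OC(C)(C)C2)cc1-c1ccc(Cl)cc1` has not yet been measured. It differs from compound 3 by a group of 10 heavy atoms (9 carbon, 1 oxygen; one six-membered non-aromatic ring with 1 hetero atom) in place of a group of 8 heavy atoms (7 carbon, 1 oxygen; one six-membered non-aromatic ring with 1 hetero atom), on an aromatic carbon. Among the compounds with values here, no measured step touches this kind of change: the only measured step, from compound 1 to compound 3, concerns drawn stereochemistry and was within the scatter. Compound 2 shows that a ring carrying four methyl groups at this position is compatible with a low number, though it also carries a different aryl group. Compound 4 is therefore expected to give a number close to that of compound 3, with the step of a 1.5-fold higher number from compound 3 to compound 4 (0.18 log units; within the scatter) expected to stay within or near the scatter. The estimate for compound 4 is 3 nM, between 1 nM and 10 nM.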

Compound 4, half-maximal inhibitory concentration: 3 nM
Estimate against measurement, compound 4: no gap at the digits printed; low and high end bracket the measured number.
By their numbers in this assay, from the lowest: compounds 2, 3, 1 and 4 (each within the scatter of the next).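

At this aromatic carbon, putting the ring of 10 heavy atoms with its double bond in place of the 2,6-dimethyloxan-4-yl group gives a 1.5-fold higher number from compound 3 to compound 4 (0.18 log units; within the scatter) and no change at the digits printed from compound 1 to compound 4 (within the scatter). Within the data shown here, the earlier step between compounds 1 and 3 touched only drawn stereochemistry, so this is the first single-place change to the ring itself, and compound 4 shows that a low number here needs neither a fully saturated ring nor defined stereocentres. Nothing measured here explains why the numbers stay so close.

Going by these compounds, the double bond and the added carbons arrive together, so their separate contributions stay open. Also open, on these data alone, is how a piperidine ring, with nitrogen in place of the ring oxygen, or an open butyl chain would read at this carbon.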